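A few compounds are considered here, and "the series" means these few. Any claim that something is new, unique, unknown or untested is made for them only; others in the source may bear on it.

Among the compounds with values here, in a functional assay on MDA-MB-231 cells (Homo sapiens) for inhibition, read by sulforhodamine B assay (on this read-out lower numbers stand for stronger inhibition of growth and higher numbers for weaker inhibition of growth), compound 1 (`COc1cccc(CN2CCC=C(CCC(=O)NO)C2=O)c1`) gives 3920 nM and this is the only number available for the series. Compound 2 (`O=C(CCC1=CCCN(Cc2ccc(F)cc2)C1=O)NO`) has no place on that scale: its entry reads "not determined" (no result reported) and no single number stands for it. Compound 3 (`COc1ccc(CN2CCC=C(CCC(=O)NO)C2=O)cc1`) differs from compound 2 by one change, methoxy in place of fluoro on an aromatic carbon in which methoxy takes the place of fluoro on an aromatic carbon, para to a large group. Within the data shown here, no measured step exists, so the size of this change in this assay cannot be read from the data. Compound 1 also carries a methoxy group, so compound 3 is expected to sit close to compound 1 at 3920 nM with no step beyond the usual scatter in either direction. The estimated value for compound 3 is 3000 nM with an expected range from 1200 nM to 8000 nM in this read-out.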

Compound 3, concentration for 50% growth inhibition: 3860 nM
The estimate for compound 3 lay 1.3-fold (0.11 log units) below the measured number; the range from low to high includes it.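

No step can be read from compound 2 to compound 3, since compound 2 has no single number in this assay. From the compounds shown here alone, the size of the change from fluoro to methoxy in this assay stays open. No outside evidence bears on the result.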